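Series notes: ethyl to isopropyl on compound 2

The compounds below may be only part of what the source reports. "The series", "measured", "known", "first", "only" and "open" are said of these compounds alone.

In a functional assay on HeLa cells (Homo sapiens) for antiproliferative activity, read by sulforhodamine B assay (a lower number here means a stronger inhibitor, a higher number a weaker inhibitor), three compounds have been measured. Compound 1 `C(=N/Nc1nc2ccccc2o1)\c1ccccn1` gives 774 nM on this scale, compound 3 `c1ccc(C(=NNc2nc3ccccc3o2)c2ccccn2)nc1` gives 156 nM on the same scale, and compound 2 `CC/C(=N\Nc1nc2ccccc2o1)c1ccccn1` gives 52 nM as the lowest number of the three. Its gaps to compound 3, the nearest, and to compound 1, the furthest, both lie beyond the usual scatter of repeats.

Compound 4 `CC(C)/C(=N\Nc1nc2ccccc2o1)c1ccccn1` has no number yet. Its structure departs from compound 2 in one place: methyl in place of hydrogen on a saturated chain carbon bound to a carbon with a double bond to nitrogen and a saturated chain carbon (read one bond further out, ethyl to isopropyl). Among the compounds with values here, no measured pair shows this change directly, so the expectation has little to rest on. The closest measured structure is compound 2 at 52 nM and the estimate is anchored there. Within the data shown here, the data hold no example of a branched chain at this place, so a wide range is kept. The expected outcome is a 1.3-fold higher number from compound 2 to compound 4 (0.10 log units; within the scatter) and this estimated step is not expected to go beyond the scatter, with little confidence in its direction. For compound 4 the estimated value is 65 nM with an expected range of 22 nM to 190 nM in this measurement.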

Compound 4, half-maximal inhibitory concentration: 185 nM
Compound 4: middle estimate off by 2.8-fold (0.45 log units), on the low side, and the stated range covers the measured number.
By their numbers in this assay, from the lowest: compound 2; then compounds 3 and 4 (each within the scatter of the next); then compound 1.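

Ethyl to isopropyl in this assay gives a 3.6-fold higher number from compound 2 to compound 4 (0.55 log units; beyond the scatter), the first direct read on a change at this position. The change is small on paper, methyl in place of hydrogen on a saturated chain carbon, adding 1 heavy atom with 0 hydrogen-bond donors, 0 hydrogen-bond acceptors and no net charge, yet the step lies beyond the scatter, so the ethyl of compound 2 cannot be branched at this carbon without a measurable shift toward weaker inhibition. Nothing available bears on the reason for this step.

On these data alone, a single pair does not separate branching from simple chain length, so it remains open whether a longer unbranched chain such as propyl would keep the number of compound 2 or shift it as the isopropyl of compound 4 does. Also open, as far as these compounds go, is how a cyclopropyl ring, or a chain ending in an amine or a carboxylic acid, would read at this same place, and no trend can yet be drawn from this one step.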